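Weak cytotoxic bis-benzylidene ketones and a vanillyl variant

The source may report more compounds than this note shows. Statements on the series, on what has been measured and on what is new or still open speak of the compounds shown alone.

Compound 3 `COc1ccc(/C=C2\CCC/C(=C\c3ccc(Br)cc3)C2=O)cc1OC` is the only one of the three measured compounds to give a number in a functional assay on A549 cells (Homo sapiens) for cytotoxicity, read by MTT assay, with a stated time of 72 h; a higher number here means a weaker inhibitor, a lower number a stronger inhibitor: compound 3 gives 16000 nM. Compound 1 `COc1ccccc1/C=C1\CCC/C(=C\c2cccc(OC)c2OC)C1=O` reaches only a limit of the assay in this assay, where compound 1 gives > 20000 nM. Compound 2 `COc1cccc(/C=C2\CCC/C(=C\c3ccc(O)cc3)C2=O)c1OC` likewise gives only a limit in this assay, where compound 2 gives > 20000 nM. The step that the two limits leave unreadable from compound 1 to compound 2 is therefore not readable, since both ends sit at the limit of > 20000 nM in this assay, at which 2 of the 3 values shown sit. Compound 4 `COc1cc(/C=C2\CCC/C(=C\c3ccc(OC)c(OC)c3)C2=O)ccc1O` differs from compound 3 in one place: 4-hydroxy-3-methoxyphenyl in place of 4-bromophenyl on a double-bonded chain carbon bound to a double-bonded ring carbon. Going by the values given here, no measured step shares this change, and the single measured step has no readable size, so there is no basis to expect a shift beyond the scatter in this assay. Compound 4 is expected to show a step of a 1.1-fold lower number from compound 3 to compound 4 (0.03 log units; within the scatter). Compound 4 is estimated at 15000 nM in this assay, between 5000 nM and 40000 nM, with a fair chance that only a limit is reported.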

Compound 4, half-maximal inhibitory concentration: 10300 nM
Beside the measured number, compound 4's estimate is 1.5-fold (0.16 log units) above it; measured number inside the range.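

In this assay, going by these compounds alone, 4-hydroxy-3-methoxyphenyl in place of 4-bromophenyl on a double-bonded chain carbon bound to a double-bonded ring carbon gives the first readable step, a 1.6-fold lower number from compound 3 to compound 4 (0.19 log units; within the scatter). Within the data shown here, at this place, then, a ring carrying bromine can give way to one carrying hydroxy and methoxy groups with no shift beyond the scatter, something the unreadable step among the earlier compounds could not show. Compound 1 and compound 2 still stand at a limit of the assay and not at a number: the limit of > 20000 nM in this assay, at which 2 of the 4 values shown sit.

From the compounds shown here alone, how a phenyl ring carrying an amine or a carboxylic acid would read at this place in this assay stays open. Going by these compounds, whether the same exchange would read alike with a different group at the other end of the shared core also stays open.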